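Urea series: dropping the ethoxycarbonyl group

This account rests on a few compounds, and the source may have more. Where it says the series, first, only, none or still open, it means among the compounds named here.

Going by the values given here, compound 2 `CCOC(=O)c1ccc(NC(=O)N2CC2C#N)cc1` gives the lowest of the two numbers so far: in a functional assay on A549 cells (Homo sapiens) for inhibition (on this read-out lower numbers stand for stronger inhibition and higher numbers for weaker inhibition), compound 2 gives 2900 nM. Its nearest neighbour is compound 1 `N#CC1CN1C(=O)Nc1ccc(Cl)c(Cl)c1`, which in this assay gives 7500 nM, a number beyond the scatter above that of compound 2. Compound 3 `N#CC1CN1C(=O)Nc1ccccc1` carries hydrogen in place of ethoxycarbonyl on an aromatic carbon. Among the compounds with values here, no step of this kind exists among the measured compounds. With both measured compounds already weak, compound 3 is expected to lose some ground, and the step from compound 2 to compound 3 is estimated at a 2.2-fold higher number from compound 2 to compound 3 (0.35 log units; beyond the scatter), a moderate weakening beyond the scatter. For compound 3 in this assay the estimate is 6500 nM, with a range from 2200 nM to 20000 nM.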

Compound 3, half-maximal inhibitory concentration: 9000 nM
Beside the measured number, compound 3's estimate is 1.4-fold (0.14 log units) below it; the measured number falls inside the stated range.
By their numbers in this assay, from the lowest: compound 2; then compounds 1 and 3 (each within the scatter of the next).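

Going by these compounds alone, this is the first one-place step: in this assay, hydrogen in place of ethoxycarbonyl on the aromatic carbon para to a group of 8 heavy atoms gives a 3.1-fold higher number from compound 2 to compound 3 (0.49 log units; beyond the scatter), so the ethoxycarbonyl group contributes at this carbon, though only modestly. Compound 3 shows that inhibition in this series does not depend entirely on that group. Nothing at hand bears on the reason for this step.

Whether the whole ester is needed remains open, as a carboxylic acid or a primary amide at this carbon is not among the compounds shown. A longer alkyl ester is also absent, so the effect of chain length here cannot be judged.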